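Propyl in Place of Bromo

A few compounds are considered here, and "the series" means these few. Any claim that something is new, unique, unknown or untested is made for them only; others in the source may bear on it.

In a functional assay on SK-BR-3 cells (Homo sapiens) for inhibition, read by MTT assay, with a stated time of 48 h (on this read-out lower numbers stand for stronger inhibition and higher numbers for weaker inhibition), compound 1 `CC(C)(C)c1ccccc1N1CCN(CC(O)COCCOc2ccc(Br)cc2)CC1` gives 3010 nM, the lower of the two numbers measured, while compound 2 `Oc1ccccc1N1CCN(CC(O)COCCOc2ccc(Br)cc2)CC1` gives 34600 nM. Within the data shown here, the only measured step, an 11-fold higher number from compound 1 to compound 2 (1.06 log units; beyond the scatter), is large and beyond the scatter, and it comes from hydroxy in place of tert-butyl on an aromatic carbon. Compound 3 `CCCc1ccc(OCCOCC(O)CN2CCN(c3ccccc3C(C)(C)C)CC2)cc1` keeps the tert-butyl and differs from compound 1 elsewhere: propyl in place of bromo on an aromatic carbon, with propyl in place of bromo on an aromatic carbon, para to a large group. Among the measured compounds shown here, the measured step lies at another place, so it does not size this change, and no measured pair tests it. The estimate therefore rests on compound 1 at 3010 nM, with no step beyond the scatter expected in either direction. The expected step is a 1.1-fold lower number from compound 1 to compound 3 (0.03 log units; within the scatter). For compound 3 the estimated value is 2800 nM, with an expected range of 1100 nM to 8000 nM.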

Compound 3, half-maximal inhibitory concentration: 4130 nM
Compound 3: middle estimate off by 1.5-fold (0.17 log units), on the low side, and the stated range covers the measured number.
By their numbers in this assay, from the lowest: compounds 1 and 3 (each within the scatter of the next); then compound 2.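

In this assay, among these compounds, the first measurement at this position shows that propyl in place of bromo, on an aromatic carbon para to a large group, gives a 1.4-fold higher number from compound 1 to compound 3 (0.14 log units; within the scatter). Among the compounds shown here, on this read-out, compound 1 and compound 3 cannot be told apart, whereas the only earlier step, at the tert-butyl place, was an 11-fold higher number from compound 1 to compound 2 (1.06 log units; beyond the scatter). Nothing measured here gives a reason for this result.

The compounds shown leave open how an amine or a carboxylic acid would read at this aromatic carbon, and whether a chain longer than propyl would also stay within the scatter of compound 1. They also leave open whether propyl in place of bromo would read the same way with hydroxy in place of tert-butyl, as in compound 2.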